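Fluorine on the Phenyl Ring of Compound 2

The source may report more compounds than this note shows. Statements on the series, on what has been measured and on what is new or still open speak of the compounds shown alone.

Measured compounds:
compound 1 `COc1cc2c(Oc3ccc(NC(=O)c4nn(-c5ccccc5)c(=O)c5ccccc45)cc3F)ccnc2cc1OCCCN1CCCC1` gives 480 nM
compound 2 `COc1cc2c(Oc3ccc(NC(=O)c4nn(-c5ccccc5)c(=O)c5ccccc45)cc3F)ccnc2cc1OCCCN1CCN(C)CC1` gives 450 nM

In a functional assay on NCI-H460 cells (Homo sapiens) for cytotoxicity, read by MTT assay, with a stated time of 72 h (on this read-out higher numbers stand for weaker inhibition and lower numbers for stronger inhibition), compound 2 gives 450 nM, and compound 1 gives 480 nM. These two values sit within the scatter of each other, as the step of a 1.1-fold lower number from compound 1 to compound 2 (0.03 log units; within the scatter) shows, so neither compound can be called stronger than the other on this read-out.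

Compound 3 `COc1cc2c(Oc3ccc(NC(=O)c4nn(-c5ccc(F)cc5)c(=O)c5ccccc45)cc3F)ccnc2cc1OCCCN1CCN(C)CC1` has not yet been measured. It differs from compound 2 in one place: fluoro in place of hydrogen on an aromatic carbon. The change sits on the phenyl ring, para to a large group, and the same difference cut one bond further out reads phenyl to 4-fluorophenyl.

Among the measured compounds shown here, no measured step touches this phenyl ring. For the measured compounds named here, the only step known, from compound 1 to compound 2, changes a group at the far end of the chain and lies within the scatter, so it gives no guidance on the ring. With nothing to point either way, compound 3 is expected to stay close to compound 2, with a step of a 1.1-fold lower number from compound 2 to compound 3 (0.05 log units; within the scatter) in this assay. Compound 3 is therefore estimated at 400 nM, with a range from 180 nM to 900 nM.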

Compound 3, half-maximal inhibitory concentration: 91 nM
Beside the measured number, compound 3's estimate is 4.4-fold (0.64 log units) above it; measured number below the stated range.
By their numbers in this assay, from the lowest: compound 3; then compounds 2 and 1 (each within the scatter of the next).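

The phenyl ring turns out to be a place where a very small edit registers in this assay: putting fluoro in place of hydrogen on an aromatic carbon, para to a large group, adds only one heavy atom, yet it gives a 4.9-fold lower number from compound 2 to compound 3 (0.69 log units; beyond the scatter) and moves the number beyond the scatter. The earlier pair showed nothing of this kind, as exchanging pyrrolidin-1-yl for 4-methylpiperazin-1-yl at the far end of the chain gave only a 1.1-fold lower number from compound 1 to compound 2 (0.03 log units; within the scatter) and stayed within the scatter. Among the compounds shown, this ring is therefore the one site where a single change separates two numbers, although no measurement here bears on the reason for the step.

As far as these compounds go, it remains open whether the step belongs to fluoro itself or would also appear with chloro, methyl or methoxy on the same carbon, and whether fluoro on another carbon of this ring would do the same. From the compounds shown here alone, it is also open whether the 4-fluorophenyl group would give a similar step on compound 1, which carries pyrrolidin-1-yl at the end of its chain.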